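Notes on the amide nitrogen substituent in the shared core

The source may report more compounds than this note shows. Statements on the series, on what has been measured and on what is new or still open speak of the compounds shown alone.

compound 1 `O=C(NCC1CCCCC1)c1cccc(/C=C2\CC(=O)N(c3ccccc3)C2=O)c1`: > 100000 nM
compound 2 `Cc1ccc(N2C(=O)C/C(=C\c3cccc(C(=O)Nc4cccc(F)c4)c3)C2=O)cc1`: 96900 nM
compound 3 `CCCCCN1C(=O)C/C(=C\c2cccc(C(=O)Nc3cccc(F)c3)c2)C1=O`: > 100000 nM

In an ADME assay on SW480 cells (Homo sapiens) for cytotoxicity, read by MTT assay, with a stated time of 72 h (on this read-out higher numbers stand for weaker inhibition and lower numbers for stronger inhibition), compound 1 gives > 100000 nM, which is a limit of the assay and not a number. Compound 2 gives 96900 nM. Compound 3 gives > 100000 nM, again a limit. Within the data shown here, the only measured step, an at least 1.0-fold higher number from compound 2 to compound 3 (0.01 log units; that floor lies within the scatter), sits within the scatter and concerns the nitrogen in the ring, not the amide nitrogen.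

Compound 4 `COc1ccc(NC(=O)c2cccc(/C=C3\CC(=O)N(c4ccccc4)C3=O)c2)c(C)c1` differs from compound 1 by 4-methoxy-2-methylphenyl in place of cyclohexylmethyl on an amide-type nitrogen. Among the measured compounds shown here, no measured step covers this change. Because (the limit of > 100000 nM in this assay, at which 2 of the 3 values shown sit), compound 4 is expected to remain near that limit, with no step beyond the scatter. Compound 4 is therefore estimated at 120000 nM, between 50000 nM and 300000 nM, an expected step that the limit leaves unreadable from compound 1 to compound 4.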

Compound 4, half-maximal inhibitory concentration: > 100000 nM
Compound 4 ended at the assay's limit; the forecaster's own chance of this, stated with the estimate: 60%; the middle value is on the limit's open side.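

In this assay compound 1 and compound 4 both sit at a limit of the assay, and no step can be read between them. The compounds shown leave open whether any substituent on the amide nitrogen changes the read-out.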